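Swapping a Pyrrolidine for a Tetrahydroisoquinoline on Two Cores

The source may hold more compounds than are shown below. What is called first, only, known or untested is meant among the compounds shown, and "the series" means these compounds.

Compound 1 `CN(c1ccc(Oc2ncnc3ccsc23)cc1)c1nccc(N2CCCC2)n1` was tested in a functional assay on A549 cells (Homo sapiens) for inhibition, read by MTT assay, with a stated time of 72 h (a higher number here means a weaker inhibitor, a lower number a stronger inhibitor), where compound 1 gives 6510 nM. Compound 2 `CN(c1ccc(Oc2ncnc3ccsc23)cc1)c1nccc(N2CCc3ccccc3C2)n1` differs from it in one place, (1,2,3,4-tetrahydroisoquinolin-2-yl in place of pyrrolidin-1-yl on an aromatic carbon), and in this assay compound 2 gives 16200 nM; the step of a 2.5-fold higher number from compound 1 to compound 2 (0.40 log units; beyond the scatter) means weaker inhibition. Compound 3 `c1cc(N2CCCC2)nc(Nc2ccc(Oc3ncnc4sccc34)cc2)n1` is built on a second core; the difference between the two cores is not broken down here. In this assay compound 3 gives 8100 nM. Compound 4 `c1ccc2c(c1)CCN(c1ccnc(Nc3ccc(Oc4ncnc5sccc45)cc3)n1)C2` carries the same change on this second core, (1,2,3,4-tetrahydroisoquinolin-2-yl in place of pyrrolidin-1-yl on an aromatic carbon), at a place described in exactly the same way. Resting on a 2.5-fold higher number from compound 1 to compound 2 (0.40 log units; beyond the scatter), a step of similar size is expected, a 2.3-fold higher number from compound 3 to compound 4 (0.37 log units; beyond the scatter). Compound 4 is therefore estimated at 19000 nM in this assay, with a likely range from 9000 nM to 45000 nM.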

Compound 4, half-maximal inhibitory concentration: 6750 nM
Estimate against measurement, compound 4: 2.8-fold (0.45 log units) above, and the stated range ends above it.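

On the second core, putting 1,2,3,4-tetrahydroisoquinolin-2-yl in place of pyrrolidin-1-yl gives a 1.2-fold lower number from compound 3 to compound 4 (0.08 log units; within the scatter) in this assay. Set beside the first core, the same change does not carry over with the same size: the same change on two cores in this assay, a 2.5-fold higher number (0.40 log units; beyond the scatter) from compound 1 to compound 2 and a 1.2-fold lower number (0.08 log units; within the scatter) from compound 3 to compound 4, 3.0-fold (0.48 log units) apart, beyond the scatter of two such steps. This shows that the step on one core was a poor guide to the step on the other, but two pairs do not show which difference between the cores is responsible or what the change would do on a further core.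

The compounds shown leave open how a piperidine or a morpholine at this place would behave on either core. They also leave open whether either group would follow the first core or the second.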